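The source may hold more compounds than are shown below. What is called first, only, known or untested is meant among the compounds shown, and "the series" means these compounds.

Measured compounds:
compound 1, `CC(C)(C)c1conc1N1C(=O)CSC1c1cccc(C(=O)NCCCCc2ccccc2)c1`: > 1000 nM
compound 2, `O=C(NCCCCc1ccccc1)c1cccc(C2SCC(=O)N2c2ccc(-c3ccccc3)cc2)c1`: > 1000 nM
compound 3, `O=C(NCCCCc1ccccc1)c1cccc(C2SCC(=O)N2c2ccccn2)c1`: 19.7 nM

Going by the values given here, in a functional assay on HOS-TE85 cells (Homo sapiens) for inhibition, read by CCK-8 assay, with a stated time of 72 h (a lower number here means a stronger inhibitor, a higher number a weaker inhibitor), compound 3 gives 19.7 nM, the only actual number in the set. Compound 1 sits at a limit of the assay, > 1000 nM. Compound 2 likewise sits at a limit, > 1000 nM; see (the limit of > 1000 nM in this assay, at which 2 of the 3 values shown sit). Compound 4, `COc1ccc(C)cc1N1C(=O)CSC1c1cccc(C(=O)NCCCCc2ccccc2)c1`, is not yet measured; it carries 2-methoxy-5-methylphenyl in place of pyridin-2-yl on an amide-type nitrogen in a ring. The measured steps that bear on it are an at least 50-fold lower number from compound 1 to compound 3 (1.70 log units; beyond the scatter) and an at least 50-fold lower number from compound 2 to compound 3 (1.70 log units; beyond the scatter), both large and beyond the scatter, each arriving at pyridin-2-yl on the amide-type nitrogen in the ring. Compound 4 runs the other way, placing an aromatic ring of carbon only on that nitrogen. For compound 4 a large rise in the number is therefore expected, a 41-fold higher number from compound 3 to compound 4 (1.61 log units; beyond the scatter), with a fair chance of another limit. Compound 4 is estimated at 800 nM, between 150 nM and 3000 nM.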

Compound 4, half-maximal inhibitory concentration: 300 nM
Beside the measured number, compound 4's estimate is 2.7-fold (0.43 log units) above it, and the stated range covers the measured number.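

On the amide-type nitrogen in the ring, an aromatic ring of carbon only can still give a readable value: 2-methoxy-5-methylphenyl brings an at least 3.3-fold lower number from compound 2 to compound 4 (0.52 log units; beyond the scatter) and an at least 3.3-fold lower number from compound 1 to compound 4 (0.52 log units; beyond the scatter). Pyridin-2-yl nevertheless stays ahead at this position, with a 15-fold higher number from compound 3 to compound 4 (1.18 log units; beyond the scatter). The values of compound 1 and compound 2 are limits, not numbers, so those two steps give only a minimum size: the limit of > 1000 nM in this assay, at which 2 of the 4 values shown sit.

As far as these compounds go, what plain phenyl or pyridin-3-yl on that nitrogen would give stays open. So do the separate shares of the methoxy and the methyl in compound 4.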